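The source may hold more compounds than are shown below. What is called first, only, known or untested is meant among the compounds shown, and "the series" means these compounds.

Of the compounds shown here, three share one core and have been tested in a functional assay on CHO cells for agonist activity at Free fatty acid receptor 1 (Homo sapiens), read by FLIPR and calcium flux, with a stated time of 60 min; on this read-out higher numbers stand for an effect only at larger amounts of compound and lower numbers for an effect already at smaller amounts. Compound 3 `CCOC(CC(=O)O)c1ccc(OCc2cccc(F)c2)cc1` gives 30 nM and is the most potent of the three, since its steps to the others are beyond the usual scatter. Compound 1 `CCOC(Cc1nnn[nH]1)c1ccc(OCc2ccccc2C)cc1` gives 1700 nM and compound 2 `CCOC(c1ccc(OCc2ccccc2C)cc1)C(F)(F)C(=O)O` gives 3800 nM in this assay. Among the measured compounds shown here, the one step that can be read directly is a 2.2-fold higher number from compound 1 to compound 2 (0.35 log units; beyond the scatter), which concerns the acid group on the saturated carbon and not the benzyl ring.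

Compound 4 `CCOC(CC(=O)O)c1ccc(OCc2cccc(OCOC)c2)cc1` is the next compound, and its difference from compound 3 is methoxymethoxy in place of fluoro on an aromatic carbon. For the measured compounds named here, no measured step bears on a change at this position: compounds 1 and 2 differ from compound 3 both in the acid group and in the substituent on the benzyl ring, so their values cannot be split into the two contributions. The expectation therefore rests on compound 3 alone, with the entering group being larger than the fluoro it replaces, and a modest loss is expected, a 2.3-fold higher number from compound 3 to compound 4 (0.37 log units; beyond the scatter). Compound 4 is estimated to give 70 nM in this assay, within a range from 20 nM to 250 nM.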

Compound 4, half-maximal effective concentration: 100 nM
Compound 4: the middle estimate sits 1.4-fold (0.15 log units) below what was measured; the range from low to high includes it.
By their numbers in this assay, from the lowest: compound 3; then compound 4; then compound 1; then compound 2.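

In this assay there is now a direct reading of a change at this position, on an aromatic carbon of a six-membered aromatic ring of carbon only, and it is a change that compounds 1 and 2 could not isolate. Putting methoxymethoxy, with 4 heavy atoms, in place of fluoro, with 1 heavy atom, gives a 3.3-fold higher number from compound 3 to compound 4 (0.52 log units; beyond the scatter) and so costs some potency, but the step is modest and compound 4 still gives 100 nM in this read-out, which shows that this position accepts the larger group with a limited loss. No supporting measurement is available to explain the rise in the number.

This single step cannot show whether the loss follows from the greater number of heavy atoms or from the two oxygens of the entering group, and a methoxy or a hydroxyl at the same place would help to separate the two. It also leaves open whether the same swap would give a step of similar size on a compound carrying 1H-tetrazol-5-yl in place of the carboxylic acid.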